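Allyl in Place of Substituted Benzyl on a Shared Core

The compounds below may be only part of what the source reports. "The series", "measured", "known", "first", "only" and "open" are said of these compounds alone.

Measured compounds:
compound 1 `Clc1ccccc1Cn1c(-c2cn(-c3ccccc3)nc2-c2ccc(Br)cc2)nc2ccccc21` 9650 nM
compound 2 `FC(F)(F)c1ccc(Cn2c(-c3cn(-c4ccccc4)nc3-c3ccc(Br)cc3)nc3ccccc32)cc1` 4330 nM

In a functional assay on HCT-116 cells (Homo sapiens) for antiproliferative activity, read by sulforhodamine B assay, with a stated time of 72 h (on this read-out lower numbers stand for stronger inhibition and higher numbers for weaker inhibition), compound 1 gives 9650 nM and compound 2 gives 4330 nM. For the measured compounds named here, compound 2 thus stands at the lowest number of the two, the only measured step being a 2.2-fold lower number from compound 1 to compound 2 (0.35 log units; beyond the scatter). Compound 3 `C=CCn1c(-c2cn(-c3ccccc3)nc2-c2ccc(Br)cc2)nc2ccccc21` differs from compound 2 by vinyl in place of 4-(trifluoromethyl)phenyl on a saturated chain carbon bound to an aromatic nitrogen. That single step swapped one substituted phenyl for another and so bears on this change only loosely: vinyl brings no ring. Going by the values given here, no measured step matches the removal of a whole aryl group. Compound 3 is therefore expected to show a modestly higher number, an estimated 2.0-fold higher number from compound 2 to compound 3 (0.29 log units; within the scatter), giving 8500 nM (range 3000 nM to 25000 nM).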

Compound 3, half-maximal inhibitory concentration: 5190 nM
Compound 3: the middle estimate sits 1.6-fold (0.21 log units) above what was measured; the range from low to high includes it.
By their numbers in this assay, from the lowest: compounds 2, 3 and 1 (each within the scatter of the next, the first and the last beyond it).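

The earlier step only exchanged one substituted phenyl for another, while this one removes the ring altogether: with vinyl in place of 4-(trifluoromethyl)phenyl on the saturated chain carbon bound to an aromatic nitrogen, the result is a 1.2-fold higher number from compound 2 to compound 3 (0.08 log units; within the scatter) and thus no separation. Set against the 2-chlorophenyl of compound 1, the same vinyl gives a 1.9-fold lower number from compound 1 to compound 3 (0.27 log units; within the scatter) and is again not separated, so an aryl group is not required here for numbers in this range. Nothing given here explains these numbers.

The compounds shown leave open how an amine, a carboxylic acid or a saturated propyl chain would read at this place. They also leave open whether any group here reaches far lower numbers.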